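Thiophene in Place of Methoxyphenyl on a Fused Core

The compounds below may be only part of what the source reports. "The series", "measured", "known", "first", "only" and "open" are said of these compounds alone.

Compound 1 `COc1ccc(-c2cn3ccnc3c(-c3ccc4ncn(C5CCCCC5)c4c3)n2)cc1` gives 95.2% in a functional assay on PC-3 cells (Homo sapiens) for inhibition, read by sulforhodamine B assay, with a stated time of 48 h, tested at 10 uM; on this read-out lower numbers stand for less inhibition and higher numbers for more inhibition at the one concentration tested (going by the name of the read-out).
Compound 2 `COc1ccccc1-c1cn2ccnc2c(-c2ccc3ncn(C4CCCCC4)c3c2)n1` gives 43.1% in this assay.

Compound 2 stands lowest of the two numbers; its nearest neighbour is compound 1, separated by the step of a number 52.1 percentage points lower from compound 1 to compound 2 (beyond the scatter). Compound 3 `c1csc(-c2cn3ccnc3c(-c3ccc4ncn(C5CCCCC5)c4c3)n2)c1` differs from compound 2 by thiophen-2-yl in place of 2-methoxyphenyl on an aromatic carbon. Among the measured compounds shown here, the only measured step, a number 52.1 percentage points lower from compound 1 to compound 2 (beyond the scatter), is large but concerns the position of the methoxy group alone, so it bears only loosely on this change. A rise in this assay is nevertheless expected for compound 3, of the size a number 21.9 percentage points higher from compound 2 to compound 3 (beyond the scatter). Compound 3 is estimated at 65%, between 30% and 95%.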

Compound 3, a percentage reported as inhibition, at one concentration (the size of the read-out at that concentration, not a potency): 49.1%
Beside the measured number, compound 3's estimate is 15.9 percentage points above it; low and high end bracket the measured number.
By their numbers in this assay, from the lowest: compounds 2 and 3 (each within the scatter of the next); then compound 1.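

In this assay, thiophen-2-yl in place of 2-methoxyphenyl on this aromatic carbon gives a number 6 percentage points higher from compound 2 to compound 3 (within the scatter), so the two groups cannot be told apart here. Set against 4-methoxyphenyl, the same change gives a number 46.1 percentage points lower from compound 1 to compound 3 (beyond the scatter), leaving compound 1 highest of the three. Nothing available explains these numbers.

From the compounds shown here alone, whether any other group at this position reaches the level of compound 1 stays open. An amine or a carboxylic acid on the phenyl ring of compound 1, for example, would test how much depends on the methoxy group itself.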